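This account rests on a few compounds, and the source may have more. Where it says the series, first, only, none or still open, it means among the compounds named here.

Compound 1 `Cc1cc(Nc2cc(Cl)cc(Br)c2)nc(N)n1` gives 33% in an assay on cells for inhibition of S-adenosylmethionine decarboxylase proenzyme (Homo sapiens), read by mass spectrometry, at pH 7.2, tested at 180 uM; a higher number here means more inhibition at the concentration tested (going by the name of the read-out), a lower number less inhibition.
Compound 2 `Cc1cc(Nc2cc(Cl)cc(C#N)c2)nc(N)n1` gives 29% in this assay.
Compound 3 `Cc1cc(Nc2cc(Cl)cc(C(F)(F)F)c2)nc(N)n1` gives 39% in this assay.

Compound 1 stands second highest of these three numbers; its nearest neighbour is compound 2, a number 4 percentage points lower from compound 1 to compound 2 (within the scatter), and its furthest is compound 3, a number 6 percentage points higher from compound 1 to compound 3 (within the scatter). Both of those steps, and also a number 10 percentage points higher from compound 2 to compound 3 (within the scatter), lie within the scatter, so all three compounds read much alike. Compound 4 `CCOc1cc(Br)cc(Nc2cc(C)nc(N)n2)c1` differs from compound 1 in one place: ethoxy in place of chloro on an aromatic carbon. Among the measured compounds shown here, no measured step touches the chloro group; the measured steps all exchange the bromo group, and each stayed within the scatter. On that basis no step beyond the scatter is expected, so compound 4 is estimated at 33%, in a range from 15% to 50%, a step of no change at the digits printed from compound 1 to compound 4 (within the scatter).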

Compound 4, a percentage reported as inhibition, at one concentration (the size of the read-out at that concentration, not a potency): 36%
For compound 4 the middle estimate is 3 percentage points below the measured one; the range from low to high includes it.
By their numbers in this assay, from the lowest: compounds 2, 1, 4 and 3 (each within the scatter of the next).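

Among the compounds shown here, compound 4 is the first compound here to change the chloro position, as the earlier steps all exchanged the bromo group. In this assay, putting ethoxy in place of chloro gives a number 3 percentage points higher from compound 1 to compound 4 (within the scatter). This position therefore takes a group with more heavy atoms and a hydrogen-bond acceptor without a shift beyond the scatter, though no measurement available here explains this.

On these data alone, whether an amine, a carboxylic acid or a longer chain at this position would shift the reading beyond the scatter remains open.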